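The compounds below may be only part of what the source reports. "The series", "measured", "known", "first", "only" and "open" are said of these compounds alone.

Working notes on the series. The shared core is carried by compound 1 `C=C1C[C@]23C[C@@]1(O)CC[C@H]2c1ccc(O)c(C)c1[C@@H]3Cn1cc(-c2ccccn2)nn1` and compound 2 `C=C1C[C@]23C[C@@]1(O)CC[C@H]2c1ccc(O)c(C)c1[C@@H]3Cn1cc(-c2ccc(C(F)(F)F)cc2)nn1`; compound 3 `C=C1C[C@]23C[C@@]1(O)CC[C@H]2c1cc(Br)c(O)c(C)c1[C@@H]3Cn1cc(-c2ccccn2)nn1` and the as yet unmeasured compound 4 `C=C1C[C@]23C[C@@]1(O)CC[C@H]2c1cc(Br)c(O)c(C)c1[C@@H]3Cn1cc(-c2ccc(C(F)(F)F)cc2)nn1` carry a second version of that core. The read-out is a functional assay on A549 cells (Homo sapiens) for cytotoxicity, read by MTT assay, with a stated time of 4 days; on this read-out lower numbers stand for stronger inhibition and higher numbers for weaker inhibition. For compound 1 the result is a limit of the assay and not a number: compound 1 gives > 20000 nM. Compound 2 gives 10400 nM in this assay. The change from compound 1 to compound 2 is 4-(trifluoromethyl)phenyl in place of pyridin-2-yl on an aromatic carbon, and it made an at least 1.9-fold lower number from compound 1 to compound 2 (0.28 log units; that floor lies within the scatter). For compound 3 the result is again a limit and not a number: compound 3 gives > 20000 nM in this assay. The two cores differ by bromo in place of hydrogen on an aromatic carbon; the matching step is a step that the two limits leave unreadable from compound 1 to compound 3, which stays unreadable since the limit of > 20000 nM in this assay, at which 2 of the 3 values shown sit, sits at both of its ends.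

Compound 4 differs from compound 3 by 4-(trifluoromethyl)phenyl in place of pyridin-2-yl on an aromatic carbon. The surroundings of the place are the same word for word as for the change from compound 1 to compound 2, so this is the same change, now made on the core of compound 3. The step from compound 3 to compound 4 is expected to be of like size, an at least 1.5-fold lower number from compound 3 to compound 4 (0.18 log units; that floor lies within the scatter), a figure that rests on the step of an at least 1.9-fold lower number from compound 1 to compound 2 (0.28 log units; that floor lies within the scatter) seen on the other core. Compound 4 is thus expected to give about 13000 nM in this assay, with a plausible range from 6000 nM to 30000 nM, and a fair chance that only a limit is reported.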

Compound 4, half-maximal inhibitory concentration: 9280 nM
The estimate for compound 4 lay 1.4-fold (0.15 log units) above the measured number; the range from low to high includes it.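

Carrying 4-(trifluoromethyl)phenyl in place of pyridin-2-yl onto the core of compound 3 gave an at least 2.1-fold lower number from compound 3 to compound 4 (0.33 log units; beyond the scatter) in this assay. The change points the same way on both cores, but this is one change on two cores and not a rule for the series, and it does not show that the steps match in size: the same change on two cores in this assay, an at least 1.9-fold lower number (0.28 log units; that floor lies within the scatter) from compound 1 to compound 2 and an at least 2.1-fold lower number (0.33 log units; beyond the scatter) from compound 3 to compound 4; the limit leaves it open whether they differ Bromo in place of hydrogen on an aromatic carbon gave a 1.1-fold lower number from compound 2 to compound 4 (0.05 log units; within the scatter), so the two compounds carrying 4-(trifluoromethyl)phenyl cannot be told apart, while the same change between the two compounds carrying pyridin-2-yl cannot be read: the limit of > 20000 nM in this assay, at which 2 of the 4 values shown sit.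

The compounds shown leave open whether the change carries over to groups other than bromo on the core, such as chloro or methoxy, since only hydrogen and bromo appear at that place. They also leave open how the read-out responds when the ring on the five-membered aromatic ring with 3 nitrogen bears an amine or a carboxylic acid instead of trifluoromethyl, or when a longer chain takes the place of that ring.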